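The source may report more compounds than this note shows. Statements on the series, on what has been measured and on what is new or still open speak of the compounds shown alone.

Measured so far in a functional assay on the whole organism for inhibition, with Lemna aequinoctialis as the target, tested at 100 ug/mL; on this read-out higher numbers stand for more inhibition of growth at the one concentration tested and lower numbers for less inhibition of growth:

- compound 1 `CCCCCCNC(=S)N/N=C1\C(=O)Nc2ccc([N+](=O)[O-])cc21`: 35%
- compound 2 `COc1ccc(NC(=S)N/N=C2\C(=O)Nc3ccc([N+](=O)[O-])cc32)cc1`: 15%
- compound 3 `O=C1Nc2ccc([N+](=O)[O-])cc2/C1=N/NC(=S)Nc1ccc(Br)cc1`: 15%

Compound 1, at 35%, stands highest of these three numbers, and it is the only one that carries a hexyl chain. The next compound to be tested is compound 4 `N#Cc1cccc(NC(=S)N/N=C2\C(=O)Nc3ccc([N+](=O)[O-])cc32)c1`, which differs from compound 1 in one place: 3-cyanophenyl in place of hexyl on an amide-type nitrogen.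

Two measured steps make the same kind of swap on that nitrogen, with 4-methoxyphenyl in one case and 4-bromophenyl in the other. They are a number 20 percentage points lower from compound 1 to compound 2 (beyond the scatter) and a number 20 percentage points lower from compound 1 to compound 3 (beyond the scatter). Both are modest but beyond the scatter. Changing the group on the aromatic ring made no real difference in no change at the digits printed from compound 2 to compound 3 (within the scatter). Going by the values given here, no nitrile-bearing compound has been measured, so this comparison is only a guide. A drop of similar size is expected, an estimated a number 19 percentage points lower from compound 1 to compound 4 (beyond the scatter). For compound 4 the expected value is 16%, with an estimated range from 5% to 30%.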

Compound 4, percent growth inhibition at one concentration: 15%
Beside the measured number, compound 4's estimate is 1 percentage points above it, within the range that was stated.
By their numbers in this assay, from the lowest: compounds 2, 3 and 4 (each within the scatter of the next); then compound 1.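

In this assay, a third phenyl-type group on the amide-type nitrogen also falls short of hexyl, a number 20 percentage points lower from compound 1 to compound 4 (beyond the scatter), so the loss seen with 4-methoxyphenyl and 4-bromophenyl extends to 3-cyanophenyl, which carries a nitrile. Among these three ring-bearing groups, the choice of group on the ring has not separated the compounds: the result is no change at the digits printed from compound 3 to compound 4 (within the scatter), and likewise no change at the digits printed from compound 2 to compound 4 (within the scatter). Nothing measured here explains the gap between hexyl and these phenyl groups.

Still open, going by these compounds, is whether a butyl or octyl chain, or a cyclohexyl ring, would match hexyl on this nitrogen. On these data alone, it is also open whether an amine or a carboxylic acid on the phenyl ring would move the number away from that shared by compounds 2, 3 and 4.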